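Terminal amine region of the shared core: compound 3 outlook

The source may report more compounds than this note shows. Statements on the series, on what has been measured and on what is new or still open speak of the compounds shown alone.

Measured so far:
compound 1 `c1ccc2c(c1)CN[C@@H](CN(CCCCNCc1ccncc1)[C@H]1CCCc3cccnc31)C2` — 22.7 nM
compound 2 `CC1(C)CCC(NCCCCN(C[C@H]2Cc3ccccc3CN2)[C@H]2CCCc3cccnc32)CC1` — 77.6 nM

Both numbers come from a functional assay on cells for antagonist activity at C-X-C chemokine receptor type 4 (Homo sapiens), read by fluorescence and calcium flux, with stated times of 25 min and 90 s; on this read-out higher numbers stand for weaker inhibition and lower numbers for stronger inhibition. For the measured compounds named here, compound 2 gives the highest of the two numbers; its nearest neighbour is compound 1, and the single measured step of a 3.4-fold higher number from compound 1 to compound 2 (0.53 log units; beyond the scatter) places compound 2 beyond the scatter above compound 1.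

Compound 3 `CC(C)(CN)CCN(C[C@H]1Cc2ccccc2CN1)[C@H]1CCCc2cccnc21` is not yet measured. It differs from compound 2 by a group of 5 heavy atoms (4 carbon, 1 nitrogen; no ring) in place of a group of 11 heavy atoms (10 carbon, 1 nitrogen; one six-membered non-aromatic ring of carbon only), on a saturated chain carbon, two bonds along the chain from an amine nitrogen.

Going by the values given here, the only step that bears on this is a 3.4-fold higher number from compound 1 to compound 2 (0.53 log units; beyond the scatter), which touched the same amine end of the chain and moved the number modestly. Among the compounds with values here, the present change is larger in what it removes, and no measured step covers a shortening of the chain. A step of a 1.9-fold higher number from compound 2 to compound 3 (0.29 log units; within the scatter) is therefore expected, toward a weaker number, but with wide uncertainty. For compound 3 the estimate in this assay is 150 nM, with a range of 40 nM to 600 nM.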

Compound 3, half-maximal inhibitory concentration: 69 nM
The estimate for compound 3 lay 2.2-fold (0.34 log units) above the measured number, within the range that was stated.
By their numbers in this assay, from the lowest: compound 1; then compounds 3 and 2 (each within the scatter of the next).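

In this assay, putting 1-(aminomethyl)-1-methylethyl (5 heavy atoms, no ring) in place of the group of 11 heavy atoms with its six-membered carbon ring gives a 1.1-fold lower number from compound 2 to compound 3 (0.05 log units; within the scatter), so at this place on the saturated chain the number does not register the loss of the ring and the 4,4-dimethyl substitution. The comparison with the pyridine-bearing end gives a 3.0-fold higher number from compound 1 to compound 3 (0.48 log units; beyond the scatter), which sits beside a 3.4-fold higher number from compound 1 to compound 2 (0.53 log units; beyond the scatter): two quite different replacements both leave the number beyond the scatter above compound 1, and among the three compounds only the 2-(((pyridin-4-yl)methyl)amino)ethyl end of compound 1 stands apart. No measurement of any other kind accompanies these steps, and nothing here accounts for them.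

Still open, from the compounds shown here alone, is whether the lower number of compound 1 belongs to the pyridin-4-yl ring itself or to the longer chain that carries it, which a benzyl group on the same chain would help separate. Also open, going by these compounds, is how much the primary amine of compound 3 contributes, a question that a hydroxyl or a carboxylic acid in its place would address.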